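A few compounds are considered here, and "the series" means these few. Any claim that something is new, unique, unknown or untested is made for them only; others in the source may bear on it.

In an ADME assay on GES1 cells (Homo sapiens) for inhibition, read by MTT assay, with a stated time of 72 h (on this read-out lower numbers stand for stronger inhibition and higher numbers for weaker inhibition), compound 1 `Cc1cc(Nc2ccn(Cc3cccc4ccccc34)n2)n2nc(SCc3ccc(Br)cc3)nc2n1` gives 30000 nM, compound 2 `Cc1cc(Nc2cc(-c3ccccc3)[nH]n2)n2nc(SCc3ccc(C(F)(F)F)cc3)nc2n1` gives 42700 nM and compound 3 `Cc1cc(Nc2cc(-c3ccccc3)[nH]n2)n2nc(SCc3csc4ccccc34)nc2n1` gives 29200 nM, so compound 1 stands within the scatter of both others. Compound 4 `Cc1cc(Nc2ccn(Cc3ccc(C(F)(F)F)cc3)n2)n2nc(SCc3ccc(Br)cc3)nc2n1` differs from compound 1 by 4-(trifluoromethyl)phenyl in place of naphthalen-1-yl on a saturated chain carbon bound to an aromatic nitrogen. Within the data shown here, only one measured step bears on this even loosely: a 1.5-fold lower number from compound 2 to compound 3 (0.17 log units; within the scatter), which exchanges a different pair of groups on a saturated chain carbon bound to a sulfur. That step stays within the scatter, so no step beyond the scatter, in either direction, is expected here. The expected step is a 1.1-fold higher number from compound 1 to compound 4 (0.03 log units; within the scatter). Compound 4 is estimated at 32000 nM, with an expected range of 17000 nM to 60000 nM.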

Compound 4, half-maximal inhibitory concentration: 30200 nM
Compound 4: the middle estimate sits 1.1-fold (0.03 log units) above what was measured, and the stated range covers the measured number.
By their numbers in this assay, from the lowest: compounds 3, 1, 4 and 2 (each within the scatter of the next).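

In this assay, the change on a saturated chain carbon bound to an aromatic nitrogen gives a 1.0-fold higher number from compound 1 to compound 4 (0.00 log units; within the scatter), so 4-(trifluoromethyl)phenyl, with one six-membered aromatic ring of carbon only, reads the same within the scatter as naphthalen-1-yl, with two such rings. Among these compounds, the earlier step concerned a different place, a saturated chain carbon bound to a sulfur, so this is the first reading at this place. Nothing measured here offers an explanation for this result. The compounds shown leave open whether an amine or a carboxylic acid in place of naphthalen-1-yl would move the number beyond the scatter.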